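Replacing the sulfonamide ring on the core nitrogen

This account rests on a few compounds, and the source may have more. Where it says the series, first, only, none or still open, it means among the compounds named here.

Compound 1 `NS(=O)(=O)c1ccccc1-n1nc(C(F)(F)F)c2c1C(=O)N(c1ccc(-c3ccccc3CN3CC[C@@H](O)C3)cc1)CC2` was measured in an in vivo ADME assay on the whole organism for pharmacokinetics, with Canis familiaris (Canis lupus familiaris) as the target (on this read-out lower numbers stand for slow clearance and higher numbers for fast clearance), and gave 4.83 mL/min/kg. Among the measured compounds shown here, the only other measured compound, compound 2 `CN(C)Cc1ccccc1-c1ccc(N2CCc3c(C(F)(F)F)nn(-c4ccccc4S(N)(=O)=O)c3C2=O)cc1`, carries a dimethylamino in place of the 3-hydroxypyrrolidin-1-yl on a saturated chain carbon bound to an aromatic carbon; in this assay compound 2 gives 8.33 mL/min/kg. The step of a 1.7-fold higher number from compound 1 to compound 2 (0.24 log units; within the scatter) stays inside the scatter, so on the numbers shown compound 1 and compound 2 cannot be told apart, and compound 1 sits alongside compound 2 rather than apart from it.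

Compound 3 `NC(=O)c1cccc(-n2nc(C(F)(F)F)c3c2C(=O)N(c2ccc(-c4ccccc4CN4CC[C@@H](O)C4)cc2)CC3)c1` has not been measured. It differs from compound 1 as follows: 3-carbamoylphenyl in place of 2-sulfamoylphenyl on an aromatic nitrogen. For the measured compounds named here, the single measured step alters the amine on the chain, not the ring on the aromatic nitrogen, so it offers no direct guide to this change. With nothing pointing either way, no step beyond the scatter is expected, though the uncertainty is wider than usual. For compound 3 the expected clearance in this assay is 6 mL/min/kg, estimated to lie between 2.5 mL/min/kg and 14 mL/min/kg. That estimate corresponds to an expected step of a 1.2-fold higher number from compound 1 to compound 3 (0.09 log units; within the scatter).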

Compound 3, clearance: 7.17 mL/min/kg
Compound 3: middle estimate off by 1.2-fold (0.08 log units), on the low side; low and high end bracket the measured number.
By their numbers in this assay, from the lowest: compounds 1, 3 and 2 (each within the scatter of the next).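

Placing 3-carbamoylphenyl in place of 2-sulfamoylphenyl on the aromatic nitrogen gives the first reading at this position in this assay, and the result is a 1.5-fold higher number from compound 1 to compound 3 (0.17 log units; within the scatter), so compound 1 and compound 3 cannot be told apart on this read-out. The ring on this nitrogen can therefore carry either of these two groups, which differ in both the attached group and its place on the phenyl ring, without a separable change in the number, though a single pair shows this for these two groups only and with the 3-hydroxypyrrolidin-1-yl amine in place. No measurement is available that would explain this result.

The swap changes two things at once, so the effect of each remains unresolved, and 2-carbamoylphenyl or 3-sulfamoylphenyl on the same nitrogen would be needed to separate them. Going by these compounds, it also remains open whether an unsubstituted phenyl ring, or a carboxylic acid on that ring, would stay within the same range, and whether 3-carbamoylphenyl would behave alike alongside the dimethylamino group of compound 2.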